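The compounds below may be only part of what the source reports. "The series", "measured", "known", "first", "only" and "open" are said of these compounds alone.

Compound 1 `CCc1cccc2c(OC)c(-c3occ(C)c3C(=O)OC)ccc12` gives 1.7 ug/mL in a functional assay on KB cells (Homo sapiens) for cytotoxicity, read by MTT assay, with a stated time of 72 h; on this read-out higher numbers stand for an effect only at larger amounts of compound and lower numbers for an effect already at smaller amounts. Compound 2 `CCc1cccc2c(OC)c(-c3occ(C)c3C(=S)OC)ccc12` gives 4.3 ug/mL in this assay, the higher of the two numbers, reached by a 2.5-fold higher number from compound 1 to compound 2 (0.40 log units; beyond the scatter). Compound 3 `CCc1cccc2c(OC)c(-c3occ(C)c3CO)ccc12` differs from compound 2 by a group of 2 heavy atoms (1 carbon, 1 oxygen; no ring) in place of a group of 4 heavy atoms (2 carbon, 1 oxygen, 1 sulfur; no ring), on an aromatic carbon. For the measured compounds named here, the single measured step only swapped one atom inside that group; no step removes the whole group, so the guide is loose. The expected step is a 1.9-fold higher number from compound 2 to compound 3 (0.27 log units; within the scatter), a modest rise, with direction and size both uncertain. For compound 3 the estimate is 8 ug/mL, within 2 ug/mL to 30 ug/mL.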

Compound 3, concentration for half-maximal effect: 7.1 ug/mL
For compound 3 the middle estimate is 1.1-fold (0.05 log units) above the measured one; the range from low to high includes it.
By their numbers in this assay, from the lowest: compound 1; then compounds 2 and 3 (each within the scatter of the next).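

In this assay hydroxymethyl in place of methoxycarbonyl gives a 4.2-fold higher number from compound 1 to compound 3 (0.62 log units; beyond the scatter) and so shows that replacing the whole group at this position, rather than swapping one atom inside it, changes the number beyond ordinary repeat variation. Set against the sulfur-containing group, the same hydroxymethyl gives a 1.7-fold higher number from compound 2 to compound 3 (0.22 log units; within the scatter) and so does not separate the two. No available measurement explains these numbers.
As far as these compounds go, whether a carboxylic acid, an amine or a longer chain here would give a lower number than methoxycarbonyl remains open.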